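The source may hold more compounds than are shown below. What is called first, only, known or untested is meant among the compounds shown, and "the series" means these compounds.

Measured so far:
- compound 1, `CCOC(=O)/C=C/c1cc(OC)c(OCc2nc(C)c(C)nc2C)c(OC)c1`: 2310000 nM
- compound 2, `CCOC(=O)/C=C/c1ccccc1OCc1nc(C)c(C)nc1C`: 1540000 nM
- compound 3, `COc1cc(/C=C/C(=O)O)cc(OC)c1OCc1nc(C)c(C)nc1C`: 3530000 nM

All three compounds were tested in a functional assay on ECV-304 cells (Homo sapiens) for cytotoxicity, read by MTT assay, with stated times of 24 h and 12 h; on this read-out lower numbers stand for an effect already at smaller amounts and higher numbers for an effect only at larger amounts of compound. In this assay compound 1 gives 2310000 nM and compound 3 gives 3530000 nM. The two share one core and differ in a single place: hydrogen in place of ethyl on an oxygen next to a carbonyl group. That change made a step of a 1.5-fold higher number from compound 1 to compound 3 (0.18 log units; within the scatter), so it left the read-out essentially where it was.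

Compound 2 gives 1540000 nM in this assay. It sits on a different core from compound 1, and the difference between the two cores is not broken down here. Compound 2 and compound 1 lie within the scatter of each other; compound 3 gives a number beyond the scatter above compound 2.

Compound 4, `Cc1nc(C)c(COc2ccccc2/C=C/C(=O)O)nc1C`, has not yet been measured. It stands to compound 2 as compound 3 stands to compound 1, with the same change made on the core of compound 2: hydrogen in place of ethyl on an oxygen next to a carbonyl group. The place of the change reads the same in both pairs, so this is the same kind of change on a different core. Because the earlier change gave only a 1.5-fold higher number from compound 1 to compound 3 (0.18 log units; within the scatter), the step from compound 2 to compound 4 is expected to be similarly small, about a 1.5-fold higher number from compound 2 to compound 4 (0.17 log units; within the scatter). On that basis compound 4 is estimated at 2300000 nM in this assay, most likely between 1200000 nM and 4500000 nM.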

Compound 4, half-maximal effective concentration: 499000 nM
Beside the measured number, compound 4's estimate is 4.6-fold (0.66 log units) above it; measured number outside the range, below it.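

Replacing the ethyl with hydrogen, which turns ethoxycarbonyl into carboxy, gave a 3.1-fold lower number from compound 2 to compound 4 (0.49 log units; beyond the scatter) in this assay. Set beside the earlier step, the same change does not carry over intact from one core to the other: the same change on two cores in this assay, a 1.5-fold higher number (0.18 log units; within the scatter) from compound 1 to compound 3 and a 3.1-fold lower number (0.49 log units; beyond the scatter) from compound 2 to compound 4, 4.7-fold (0.67 log units) apart, beyond the scatter of two such steps. This shows that in these two pairs the result of the change depends on the core that carries it, so a step read on one core is a poor guide to the step on the other, but it does not show which part of the cores makes the difference, and two pairs give no rule for any further core.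

The compounds shown leave open what other groups would do at this same oxygen, for example a methyl or a longer chain in place of the ethyl, and whether an amide formed with an amine would follow compound 2 and compound 4 or compound 1 and compound 3. They also leave open how the change from ethoxycarbonyl to carboxy would behave on a third core, which would help to show whether either of the two steps seen so far is the more typical one.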